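Compound 2 to compound 3: exchange on the sulfur chain

The source may report more compounds than this note shows. Statements on the series, on what has been measured and on what is new or still open speak of the compounds shown alone.

The core of compound 1 (`Cc1ccc(-c2cc(-c3ccccc3)nc(SCC(=O)O)c2C#N)cc1`) carries a carboxy group on a saturated chain carbon bound to a sulfur. In an ADME assay on MDCK cells (Canis lupus familiaris) for cytotoxicity, read by MTT assay, with a stated time of 48 h (a lower number here means that less compound is tolerated, a higher number that more compound is tolerated), compound 1 gives > 250000 nM, which is a limit of the assay and not a number. Compound 2 (`Cc1ccc(-c2cc(-c3ccccc3)nc(SCNC(=O)OC(C)(C)C)c2C#N)cc1`) carries (tert-butoxycarbonyl)amino in that place. In this assay compound 2 gives > 250000 nM, again a limit. Compound 2 therefore has no number of its own, and the position of the series is the limit of > 250000 nM in this assay, at which 2 of the 2 values shown sit.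

Compound 3 (`Cc1ccc(-c2cc(-c3ccccc3)nc(SCC(N)=O)c2C#N)cc1`) has carbamoyl in place of (tert-butoxycarbonyl)amino on a saturated chain carbon bound to a sulfur. Within the data shown here, the only measured step that bears on this exchange is a step that the two limits leave unreadable from compound 1 to compound 2, so no size can be carried over from it. With both measured compounds at the same limit, no step beyond the scatter is expected in this assay. The estimated step is a number no higher from compound 2 to compound 3 (the limit leaves the size open). The estimate for compound 3 is 250000 nM, with an expected range of 120000 nM to 500000 nM.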

Compound 3, half-maximal cytotoxic concentration: > 250000 nM
Compound 3: a limit, no number; the forecaster's own chance of this, stated with the estimate: 80%; the middle value lies on the limit itself.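

No new step can be read among compound 1, compound 2 and compound 3, as all three values are limits of the assay and not numbers: the limit of > 250000 nM in this assay, at which 3 of the 3 values shown sit.

The compounds shown leave open whether any group on a saturated chain carbon bound to a sulfur would give a readable number in this assay, and how far these three compounds differ.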